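The source may hold more compounds than are shown below. What is called first, only, known or untested is meant among the compounds shown, and "the series" means these compounds.

The study concerns two measured compounds and one that has yet to be measured in a functional assay on CHO cells for agonist activity at Free fatty acid receptor 1 (Homo sapiens), read by FLIPR and calcium flux, tested at 100 nM; a lower number here means a weaker effect, a higher number a stronger effect of the compound at the concentration tested. Compound 1 `O=C(O)CC1COc2cc(OCc3cc(-c4ccccc4)on3)ccc21` is one of them; in this assay compound 1 gives 0.84%. Compound 2 `Cc1ccccc1-c1nc(C)c(COc2ccc3c(c2)OCC3CC(=O)O)s1` is the other; in this assay compound 2 gives 10.7%. On the two numbers shown, compound 2 holds the larger value, but its gap to compound 1 lies within the usual scatter of repeated measurements, so the two cannot be set apart, and nothing more than their two values should be read into the pair.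

Compound 3 `COc1ccc(-c2nc(C)c(COc3ccc4c(c3)OCC4CC(=O)O)s2)cc1` differs from compound 2 in one place: 4-methoxyphenyl in place of 2-methylphenyl on an aromatic carbon. Both compounds keep the same acid-bearing core and the same five-membered aromatic ring bearing a methyl group; only the aryl group on that ring is exchanged.

Among the measured compounds shown here, with no comparable pair among the measured compounds, the step from compound 2 to compound 3 in this assay is expected to be small, in either direction, and most likely not beyond the scatter, so that a number 1.3 percentage points higher from compound 2 to compound 3 (within the scatter) is the estimate. Compound 3 is therefore expected to give 12%, within a range from 0% to 35%.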

Compound 3, a percentage reported as activity, at one concentration (the size of the read-out at that concentration, not a potency): 46.8%
Estimate against measurement, compound 3: 34.8 percentage points below, outside the stated range (above it).
By their numbers in this assay, from the lowest: compounds 1 and 2 (each within the scatter of the next); then compound 3.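

In this assay, the aromatic carbon next to the ring nitrogen and next to the ring sulfur proves sensitive to the choice of aryl group: 4-methoxyphenyl in place of 2-methylphenyl gives a number 36.1 percentage points higher from compound 2 to compound 3 (beyond the scatter), a large step. Compounds 1 and 2 could not be set apart, so this exchange provides the first difference beyond the scatter among the compounds shown, and it shows that the read-out can change substantially with the shared core and the methyl-bearing ring held constant. The exchange alters both the substituent and its location on the phenyl ring, and no independent data bear on why the read-out rises.

The compounds shown leave open which part of the exchange carries the step, a question that 4-methylphenyl, 2-methoxyphenyl or unsubstituted phenyl at this carbon would help to separate. They also leave open whether a longer group such as 4-ethoxyphenyl would extend the step, and, with the read-out taken at one concentration, how compound 2 and compound 3 compare in potency.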